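The source may hold more compounds than are shown below. What is called first, only, known or untested is meant among the compounds shown, and "the series" means these compounds.

Measured so far in a functional assay on SMMC-7721 cells (Homo sapiens) for inhibition, read by MTT assay, with a stated time of 72 h, tested at 25 uM; on this read-out lower numbers stand for less inhibition and higher numbers for more inhibition at the one concentration tested (going by the name of the read-out):
- compound 1 `Cc1nn(C)c(Oc2ccc(Cl)cc2)c1/C=N\OCc1c(Cl)c(-c2ccc(F)cc2)nn1C` gives 80%
- compound 2 `Cc1nn(C)c(Oc2ccc(F)cc2)c1/C=N\OCc1c(Cl)c(-c2ccc(Cl)cc2)nn1C` gives 80%
- compound 3 `Cc1nn(C)c(Oc2ccc(Cl)cc2)c1/C=N\OCc1c(Cl)c(-c2ccc(Cl)cc2)nn1C` gives 80%

Compound 3 stands level with compounds 1 and 2 on the numbers shown; nothing separates the three in this assay. The two single-point steps into compound 3, no change at the digits printed from compound 1 to compound 3 (within the scatter) and no change at the digits printed from compound 2 to compound 3 (within the scatter), both swap chloro for fluoro on an aromatic carbon and both leave the read-out unchanged within the scatter, so the halogen on either outer ring has so far not mattered.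

Compound 4 `Cc1ccc(Oc2c(/C=N\OCc3c(Cl)c(-c4ccc(Cl)cc4)nn3C)c(C)nn2C)cc1` is the next step from compound 3: methyl in place of chloro on an aromatic carbon. For the measured compounds named here, no measured step exchanges chloro for methyl, so the two halogen steps bear on it only in a general way; they show that small changes at this aromatic carbon have not shifted this assay, and the same is expected here. The step from compound 3 to compound 4 is therefore expected to be a number 2 percentage points lower from compound 3 to compound 4 (within the scatter), no change beyond the scatter. Compound 4 is estimated at 78% in this assay, in the range 60% to 90%.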

Compound 4, a percentage reported as inhibition, at one concentration (the size of the read-out at that concentration, not a potency): 80%
Beside the measured number, compound 4's estimate is 2 percentage points below it, and the stated range covers the measured number.
By their numbers in this assay, from the lowest: compounds 1, 2, 3 and 4 (each within the scatter of the next).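

For the compounds shown here, at this position, para to a large group, the earlier steps exchanged only one halogen for another, and a carbon substituent now joins them. In this assay, the change from 4-chlorophenoxy to 4-methylphenoxy gives no change at the digits printed from compound 3 to compound 4 (within the scatter), and methyl in place of fluoro at the same aromatic carbon gives no change at the digits printed from compound 2 to compound 4 (within the scatter), so this read-out does not separate fluoro, chloro and methyl here. No supporting data bear on why these three groups read alike.

On these data alone, whether an amine, a carboxylic acid or a longer chain such as butyl at this aromatic carbon would hold the read-out remains open. Also open, as far as these compounds go, is whether methyl on the 4-chlorophenyl ring would read the same, and a single concentration gives no potency order for these compounds.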